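The source may hold more compounds than are shown below. What is called first, only, known or untested is meant among the compounds shown, and "the series" means these compounds.

Compound 1 `CC(C)N(Cc1cccc(OCCCCCC(=O)O)c1)C(=O)c1ccc(-c2cccc(OC(F)(F)F)c2)cc1` carries a free carboxylic acid at the end of its chain. In an ADME assay on HEK293 cells (Homo sapiens) for cytotoxicity, read by CellTiter-Glo and resazurin assay, with a stated time of 72 h (on this read-out lower numbers stand for an effect already at smaller amounts and higher numbers for an effect only at larger amounts of compound), compound 1 gives only a limit, > 26000 nM. Compound 2 `COc1cc(F)cc(-c2ccc(C(=O)N(Cc3cccc(OCCCCCC(=O)O)c3)C(C)C)cc2)c1` differs from compound 1 by 3-fluoro-5-methoxyphenyl in place of 3-(trifluoromethoxy)phenyl on an aromatic carbon. In this assay compound 2 also reaches only a limit, > 26000 nM. The step that the two limits leave unreadable from compound 1 to compound 2 therefore has no readable size. Compound 3 `CCOC(=O)CCCCCOc1cccc(CN(C(=O)c2ccc(-c3cccc(OC(F)(F)F)c3)cc2)C(C)C)c1` is the ethyl ester of compound 1; the two cores differ by ethyl in place of hydrogen on an oxygen next to a carbonyl group. In this assay compound 3 likewise gives only a limit, > 26000 nM. The step that the two limits leave unreadable from compound 1 to compound 3 is equally unreadable, since every value sits at the limit of > 26000 nM in this assay, at which 3 of the 3 values shown sit.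

Compound 4 `CCOC(=O)CCCCCOc1cccc(CN(C(=O)c2ccc(-c3cc(F)cc(OC)c3)cc2)C(C)C)c1` has not been measured. It differs from compound 3 by 3-fluoro-5-methoxyphenyl in place of 3-(trifluoromethoxy)phenyl on an aromatic carbon, the same change that separates compound 1 from compound 2, at a place described in the same words. From compound 3 to compound 4 the expected step is a step that the limit leaves unreadable from compound 3 to compound 4, no larger than the unreadable step seen from compound 1 to compound 2. That expectation rests on compound 3, whose value > 26000 nM is a limit. It rests also on compound 2, whose value > 26000 nM is a limit. Compound 4 is thus expected to give about 30000 nM, most likely again only as a limit, between 20000 nM and 60000 nM.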

Compound 4, half-maximal effective concentration: > 26000 nM
Compound 4 was reported as a limit; the forecaster's own chance of this, stated with the estimate: 85%; the middle value lies beyond the limit too.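

In this assay compound 4 gives > 26000 nM, which is a limit. No step from compound 2 or compound 3 to compound 4 can be read, because all the values sit at the same limit: the limit of > 26000 nM in this assay, at which 4 of the 4 values shown sit.

The compounds shown leave open whether the aryl exchange or the ethyl ester changes the effective concentration in this assay at all.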